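Aminopyrimidine series: fluoro to amino on the aniline

A few compounds are considered here, and "the series" means these few. Any claim that something is new, unique, unknown or untested is made for them only; others in the source may bear on it.

Three measured compounds share one core. Compound 1 `Fc1cccc(Nc2nccc(-c3ccccn3)n2)c1` gives 1000 nM in a functional assay for inhibition, with Homo sapiens as the target; on this read-out higher numbers stand for weaker inhibition and lower numbers for stronger inhibition. Compound 2 `COc1cccc(Nc2nccc(-c3ccc(C)o3)n2)c1` gives 1500 nM in this assay, and compound 3 `CC1CCN(c2ccc(Nc3nccc(-c4cccnc4)n3)cc2)CC1` gives 500 nM; both of these numbers lie within the usual scatter of the number for compound 1, so compound 1 stands in the middle of a group that the assay cannot separate. Going by the values given here, no single-point step between measured compounds is available. Compound 4 `Nc1cccc(Nc2nccc(-c3ccccn3)n2)c1` differs from compound 1 by amino in place of fluoro on an aromatic carbon. Among the compounds with values here, with no measured precedent for this change, the step of a 1.1-fold lower number from compound 1 to compound 4 (0.05 log units; within the scatter) is expected to be small, in either direction and not beyond the scatter. Compound 4 is estimated at 900 nM, with a range from 300 nM to 3000 nM.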

Compound 4, half-maximal inhibitory concentration: 300 nM
Beside the measured number, compound 4's estimate is 3.0-fold (0.48 log units) above it; measured number inside the range.
By their numbers in this assay, from the lowest: compounds 4, 3, 1 and 2 (each within the scatter of the next, the first and the last beyond it).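

Amino in place of fluoro on this aromatic carbon, meta to a large group, gives the first single-place reading in the series: in this assay it is a 3.3-fold lower number from compound 1 to compound 4 (0.52 log units; beyond the scatter), a modest step. This position therefore responds to a change of one heavy atom, with the entering amino bringing a hydrogen-bond donor and acceptor. Nothing available bears on the reason for this step.

Going by these compounds, a hydroxyl, a methylamino or an acetamide on this carbon remains open. So does whether the same change would give a similar step with the other ring of compound 2 or compound 3.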